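This account rests on a few compounds, and the source may have more. Where it says the series, first, only, none or still open, it means among the compounds named here.

In a functional assay on DU-145 cells (Homo sapiens) for cytotoxicity, read by MTT assay, with a stated time of 48 h (on this read-out higher numbers stand for weaker inhibition and lower numbers for stronger inhibition), compound 1 (`C=C(c1ccc(OC)cc1)c1cc(OC)c(OC)c(OC)c1-c1ccc(F)c(F)c1`) gives 6800 nM, compound 2 (`C=C(c1ccc(OC)cc1)c1cc(OC)c(OC)c(OC)c1-c1ccccc1`) gives 8000 nM and compound 3 (`C=C(c1ccc(OC)cc1)c1cc(OC)c(OC)c(OC)c1-c1ccc2ccccc2c1`) gives 46000 nM. Compound 3 thus has the highest number of the three and is the weakest inhibitor among them. Compound 4 (`C=C(c1ccc(OC)cc1)c1cc(OC)c(OC)c(OC)c1-c1ccc(Cl)cc1`) carries 4-chlorophenyl in place of naphthalen-2-yl on an aromatic carbon, ortho to a 1-(4-methoxyphenyl)ethenyl group (4-chlorophenyl in place of naphthalen-2-yl on an aromatic carbon). Within the data shown here, three measured steps bear on this change. Bringing in naphthalen-2-yl gave a 5.8-fold higher number from compound 2 to compound 3 (0.76 log units; beyond the scatter) and a 6.8-fold higher number from compound 1 to compound 3 (0.83 log units; beyond the scatter), both modest and beyond the scatter. Exchanging 3,4-difluorophenyl for phenyl gave a 1.2-fold higher number from compound 1 to compound 2 (0.07 log units; within the scatter), which lies within the scatter. Among the measured compounds shown here, the entering 4-chlorophenyl resembles those two groups more than it resembles naphthalen-2-yl, so the change is expected to reverse most of the rise seen with compound 3, though no chlorinated compound has yet been measured. The expected change is a modest fall, a 5.8-fold lower number from compound 3 to compound 4 (0.76 log units; beyond the scatter). The estimate for compound 4 is 8000 nM, with an expected range of 3500 nM to 18000 nM.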

Compound 4, half-maximal inhibitory concentration: 33000 nM
For compound 4 the middle estimate is 4.1-fold (0.62 log units) below the measured one, and the stated range ends below it.
By their numbers in this assay, from the lowest: compounds 1 and 2 (each within the scatter of the next); then compounds 4 and 3 (each within the scatter of the next).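

At this position a single aromatic ring does not by itself keep the number low: 4-chlorophenyl lands within the scatter of naphthalen-2-yl, with a 1.4-fold lower number from compound 3 to compound 4 (0.14 log units; within the scatter) as the step. One chloro on the phenyl ring is enough to move the number, with a 4.1-fold higher number from compound 2 to compound 4 (0.62 log units; beyond the scatter) for chloro in place of hydrogen and a 4.9-fold higher number from compound 1 to compound 4 (0.69 log units; beyond the scatter) against 3,4-difluorophenyl, so halogen on this ring does not act alike in every case, since compound 1 stays within the scatter of compound 2. Nothing available here explains this difference between the chloro and difluoro compounds.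

On these data alone, it remains open whether the rise belongs to chloro alone or would also appear with another group on the phenyl ring. A bromo, an amine or a carboxylic acid there could fall with either pair.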